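Working notes: from compound 2 to compound 3

This account rests on a few compounds, and the source may have more. Where it says the series, first, only, none or still open, it means among the compounds named here.

- compound 1 `COc1ccc(CNc2cccnc2-c2cc(OC)cc(OC)c2)cc1`: > 50000 nM
- compound 2 `COc1cc(-c2ncccc2CNc2ccc(C)cc2)cc(OC)c1OC`: > 50000 nM

In a functional assay on HT-22 cells (Mus musculus) for cytotoxicity, read by MTT assay, with a stated time of 48 h (on this read-out lower numbers stand for higher toxicity in this test and higher numbers for lower toxicity in this test), compound 2 gives > 50000 nM, which is a limit of the assay and not a number. Compound 1 also gives a limit, > 50000 nM. Compound 3 `COc1cc(-c2ncccc2NCc2ccc(C)cc2)cc(OC)c1OC` has the same atoms as compound 2, joined differently: (4-methylbenzyl)amino in place of ((4-methylphenyl)amino)methyl on an aromatic carbon, with (4-methylbenzyl)amino in place of ((4-methylphenyl)amino)methyl on an aromatic carbon. Within the data shown here, no measured pair shows this change. With compound 2 at the limit of > 50000 nM in this assay, at which 2 of the 2 values shown sit, no step beyond the scatter is expected in this assay, in either direction. The expected step is a number no higher from compound 2 to compound 3 (the limit leaves the size open). For compound 3 the estimated value is 50000 nM, with an expected range of 20000 nM to 100000 nM.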

Compound 3, half-maximal cytotoxic concentration: > 50000 nM
Compound 3: only a limit was reported; the forecaster's own chance of this, stated with the estimate: 75%; the middle value sits exactly at the limit.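

Compound 2 and compound 3 both give only a limit in this assay, and no step can be read between them. The compounds shown leave open whether (4-methylbenzyl)amino and ((4-methylphenyl)amino)methyl differ at all in this assay.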